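This account rests on a few compounds, and the source may have more. Where it says the series, first, only, none or still open, it means among the compounds named here.

Working notes on the series. Going by the values given here, compound 3 `Cc1nn(C)c(Oc2cccc(F)c2)c1/C=N\CCCCCCOc1cc2oc(=O)cc(C)c2cc1Cl` gives 23600 nM in a functional assay on SMMC-7721 cells (Homo sapiens) for antiproliferative activity, read by MTT assay, with a stated time of 72 h (a higher number here means a weaker inhibitor, a lower number a stronger inhibitor), the highest of the three numbers measured so far. Compound 1 `Cc1nn(C)c(Oc2ccc(F)cc2)c1/C=N\CCCCCOc1cc2oc(=O)cc(C)c2cc1Cl` gives 22100 nM, which sits within the scatter of compound 3; compound 2 `Cc1ccc(Oc2c(/C=N\CCCCCOc3cc4oc(=O)cc(C)c4cc3Cl)c(C)nn2C)cc1` gives 11100 nM, a gap beyond the scatter. Among the compounds with values here, the only single-point step measured, a 2.0-fold lower number from compound 1 to compound 2 (0.30 log units; within the scatter), exchanges fluoro for methyl and stays within the scatter.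

Compound 4 `Cc1nn(C)c(Oc2cccc(Br)c2)c1/C=N\CCCCCCOc1cc2oc(=O)cc(C)c2cc1Cl` differs from compound 3 by bromo in place of fluoro on an aromatic carbon. Within the data shown here, no measured step exchanges one halogen for another, so the fluoro-to-methyl step is the nearest guide, and it was small. The step of a 1.2-fold lower number from compound 3 to compound 4 (0.07 log units; within the scatter) is therefore expected to stay within the scatter. For compound 4 the estimate in this assay is 20000 nM, with a range from 8000 nM to 50000 nM.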

Compound 4, half-maximal inhibitory concentration: 5080 nM
Estimate against measurement, compound 4: 3.9-fold (0.60 log units) above, outside the stated range (below it).
By their numbers in this assay, from the lowest: compound 4; then compounds 2, 1 and 3 (each within the scatter of the next, the first and the last beyond it).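

Going by these compounds alone, the exchange of fluoro for bromo on the 3-fluorophenoxy group gives a clear change in this assay (a 4.6-fold lower number from compound 3 to compound 4 (0.67 log units; beyond the scatter)), the first step that lies beyond the scatter. Within the data shown here, this aromatic carbon therefore responds to the choice of substituent, which the only earlier step (a 2.0-fold lower number from compound 1 to compound 2 (0.30 log units; within the scatter)), taken on a different compound and within the scatter, did not show. Nothing on hand accounts for the stronger inhibition seen with bromo.

On these data alone, whether iodo or trifluoromethyl at this place would match bromo remains open. So does whether the bromo gain carries over to a shorter chain.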